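A few compounds are considered here, and "the series" means these few. Any claim that something is new, unique, unknown or untested is made for them only; others in the source may bear on it.

Of the compounds shown here, three have so far been tested in a functional assay on HOP-92 cells (Homo sapiens) for inhibition, read by sulforhodamine B assay, with a stated time of 48 h, tested at 10 uM; on this read-out lower numbers stand for less inhibition of growth and higher numbers for more inhibition of growth at the one concentration tested. Compound 1 `COc1ccc(-c2nc3sc(-c4ccccc4)cn3n2)cc1` gives 32%, the highest of the three numbers. Compound 2 `COc1cc(-c2nc(N)n(CC(=O)Nc3ccc(/C(C)=N\O)cc3)n2)cc(OC)c1OC` gives 11.8%, and compound 3 `C/C(=N/O)c1ccc(NC(=O)Cn2nc(-c3ccccc3)nc2N)cc1` gives 5.82%. Both of these lie lower than compound 1 by more than the usual scatter of such measurements, while the two cannot be told apart from each other. Compound 1 therefore stands at the top of this small set, although its inhibition of growth is only partial at the one concentration tested.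

Compound 4 `COc1ccc(-c2nc3sc(-c4ccc(Cl)cc4)cn3n2)cc1` has not yet been measured. It keeps the structure of compound 1 apart from one change: chloro in place of hydrogen on an aromatic carbon. In plain terms, this is chloro in place of hydrogen on an aromatic carbon, which turns a phenyl into a 4-chlorophenyl. Within the data shown here, no pair of tested compounds shows this change, and compound 2 and compound 3 are too different from compound 1 to serve as a direct guide. The expectation therefore rests on compound 1 at 32%, and a single substitution of this kind is expected to produce a small upward move that stays within the scatter. The estimated step of a number 8 percentage points higher from compound 1 to compound 4 (within the scatter) reflects that view, with real uncertainty in either direction. For compound 4 the expected value is 40%, with an estimated range from 20% to 60%.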

Compound 4, percent growth inhibition at one concentration: 79.5%
Estimate against measurement, compound 4: 39.5 percentage points below; measured number above the stated range.
By their numbers in this assay, from the lowest: compounds 3 and 2 (each within the scatter of the next); then compound 1; then compound 4.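

In this assay, replacing hydrogen with chloro on an aromatic carbon, para to a large group, gives a number 47.5 percentage points higher from compound 1 to compound 4 (beyond the scatter), so this position on the phenyl of compound 1 is highly responsive to change. A single added heavy atom, which turns the phenyl into a 4-chlorophenyl, is enough to move the result well beyond the scatter, and it takes the partial inhibition of compound 1 at 32% to the much higher level of compound 4 at 79.5%. The data at hand offer no measurement that accounts for the size of this step.

Among these compounds, with only this one pair, it remains open whether the gain belongs to chloro itself or would also appear with another group at the same place, such as bromo, a nitrile or a carboxylic acid. Going by these compounds, it is also open whether chloro elsewhere on this ring would give a similar result, and how compound 4 would behave at other concentrations, since a single concentration does not show how the effect changes with dose.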